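Working notes: from compound 1 to compound 4

A few compounds are considered here, and "the series" means these few. Any claim that something is new, unique, unknown or untested is made for them only; others in the source may bear on it.

Measured so far:
Compound 1, `CCCCCCCCCNC(=O)N(Cc1cc(OC)ccc1OC)n1cnnc1` — in a functional assay on MCF7 cells (Homo sapiens) for cytotoxicity, read by MTT assay, with a stated time of 48 h (a higher number here means a weaker inhibitor, a lower number a stronger inhibitor), compound 1 gives > 50000 nM, which is a limit of the assay and not a number.
Compound 2, `COc1cc(CN(C(=O)Nc2ccc(C)cc2)n2cnnc2)cc(OC)c1OC` — in this assay compound 2 gives > 50000 nM, again only a limit.
Compound 3, `COc1ccc(CN(C(=O)Nc2ccc(Cl)cc2)n2cnnc2)cc1OC` — in this assay compound 3 gives > 50000 nM, again only a limit.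

Among the measured compounds shown here, compound 1 stands at the limit of > 50000 nM in this assay, at which 3 of the 3 values shown sit; nothing in these numbers sets it apart from compound 2 or compound 3, and no measured step can be sized. Compound 4, `COc1ccc(OC)c(CN(C(=O)Nc2ccc(C)cc2)n2cnnc2)c1`, differs from compound 1 by 4-methylphenyl in place of nonyl on an amide-type nitrogen. For the measured compounds named here, since every value so far is a limit, the step from compound 1 to compound 4 in this assay is expected to be none beyond the scatter, a step that the limit leaves unreadable from compound 1 to compound 4. Compound 4 is therefore expected at 60000 nM, within 20000 nM to 200000 nM, most probably reported again only as a limit.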

Compound 4, half-maximal inhibitory concentration: > 50000 nM
Compound 4 gave a limit, no number (the forecaster's own chance of this, stated with the estimate: 85%); the middle value is on the limit's open side.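

Compound 1 and compound 4 each give only a limit of the assay, and no step can be read between them. The compounds shown leave open whether any change to the shared core yields a measurable value in this assay.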